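The compounds below may be only part of what the source reports. "The series", "measured", "known", "first", "only" and "open" are said of these compounds alone.

Measured so far, in a functional assay (Pituitary gland cell) with Rattus norvegicus as the target; on this read-out higher numbers stand for an effect only at larger amounts of compound and lower numbers for an effect already at smaller amounts:
- compound 1 `CC(C)(N)CC(=O)N[C@@H]1CCc2ccccc2N(Cc2ccc(-c3ccccc3C(N)=O)cc2)C1=O` gives 0.08 uM
- compound 2 `Cn1nnc(-c2ccccc2-c2ccc(CN3C(=O)[C@H](NC(=O)CC(C)(C)N)CCc4ccccc43)cc2)n1` gives 0.3 uM
- compound 3 `CC(O)Cn1nnc(-c2ccccc2-c2ccc(CN3C(=O)[C@H](NC(=O)CC(C)(C)N)CCc4ccccc43)cc2)n1` gives 0.05 uM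

Compound 3 has the lowest number of the three, although its gap to compound 1 is within the scatter; only compound 2 sits clearly apart, with a 6.0-fold lower number from compound 2 to compound 3 (0.78 log units; beyond the scatter). Compound 4 `CC(C)(N)CC(=O)N[C@@H]1CCc2ccccc2N(Cc2ccc(-c3ccccc3S(N)(=O)=O)cc2)C1=O` differs from compound 3 as follows: sulfamoyl in place of 2-(2-hydroxypropyl)-2H-tetrazol-5-yl on an aromatic carbon. Within the data shown here, no measured step swaps a tetrazole for sulfamoyl, but compound 1 carries carbamoyl at the same position, and a 1.6-fold lower number from compound 1 to compound 3 (0.20 log units; within the scatter) shows that removing the whole tetrazole branch there cost little. Sulfamoyl is closest to that case, so in this assay a modest step upward of about a 2.4-fold higher number from compound 3 to compound 4 (0.38 log units; beyond the scatter) is expected rather than a large one. Compound 4 is estimated at 0.12 uM, plausibly between 0.04 uM and 0.4 uM.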

Compound 4, concentration for half-maximal effect: 3 uM
Compound 4: the middle estimate sits 25-fold (1.40 log units) below what was measured; measured number above the stated range.
By their numbers in this assay, from the lowest: compounds 3 and 1 (each within the scatter of the next); then compound 2; then compound 4.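

At this position, an aromatic carbon ortho to a large group, sulfamoyl does not stand in for carbamoyl in this assay (a 38-fold higher number from compound 1 to compound 4 (1.57 log units; beyond the scatter)). The earlier compounds shown here showed only that carbamoyl and the 2-(2-hydroxypropyl)-2H-tetrazol-5-yl group give values within the scatter of each other, whereas sulfamoyl also sits clearly apart from both tetrazoles (a 10-fold higher number from compound 2 to compound 4 (1.00 log units; beyond the scatter); a 60-fold higher number from compound 3 to compound 4 (1.78 log units; beyond the scatter)). Nothing available accounts for this drop. Open, going by these compounds, is whether a carboxylic acid or a nitrile at this place would track carbamoyl or sulfamoyl.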